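Sulfur for oxygen in the ring beside the sulfonyl

A few compounds are considered here, and "the series" means these few. Any claim that something is new, unique, unknown or untested is made for them only; others in the source may bear on it.

Measured compounds:
- compound 1 `O=S(=O)(CC1=NCCO1)c1n[nH]cc1-c1ccc(Cl)cc1`: in a functional assay, read by Griess assay, with a stated time of 150 min, tested at 50 ug/mL (a lower number here means a weaker effect, a higher number a stronger effect of the compound at the concentration tested), compound 1 is reported as "not active" (no number reported)
- compound 2 `O=S(=O)(CC1=NCCO1)c1n[nH]cc1-c1ccccc1`: in this assay compound 2 gives 50.6%

Compound 1 stands on no single number in this assay; the read-out for it is a statement of no activity rather than a percentage, so its position relative to compound 2 cannot be put as a distance. Among the measured compounds shown here, compound 2 differs from compound 1 in the aryl part, and no step between the two is worked out here; what the two values show is a measurable effect for compound 2 and none recorded for compound 1.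

Compound 3 `O=S(=O)(CC1=NCCS1)c1n[nH]cc1-c1ccc(Cl)cc1` is not yet measured. It differs from compound 1 as follows: a group of 5 heavy atoms (3 carbon, 1 nitrogen, 1 sulfur; one five-membered non-aromatic ring with 2 hetero atoms) in place of a group of 5 heavy atoms (3 carbon, 1 nitrogen, 1 oxygen; one five-membered non-aromatic ring with 2 hetero atoms), on a saturated chain carbon bound to a sulfonyl sulfur. For the measured compounds named here, no step is available for this change. The expectation is for no shift beyond the scatter of this assay, in either direction, given that compound 1 sits at no activity and the change is confined to one atom of the ring on the chain carbon.

For compound 3 the estimated read-out in this assay is 12%, expected within 0% to 40%, with a real chance that, as for compound 1, only a statement of no activity is returned.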

Compound 3, a percentage reported as activity, at one concentration (the size of the read-out at that concentration, not a potency): "not active" (no number reported)
Compound 3: no number reported, and the estimate cannot be compared.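

No step can be read between compound 1 and compound 3: in this assay compound 1 gives "not active" (no number reported) and compound 3 gives "not active" (no number reported). Nothing shown here bears on this result. The compounds shown leave open whether sulfur for oxygen in this ring changes the read-out of a compound with measurable activity, such as compound 2.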